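A few compounds are considered here, and "the series" means these few. Any claim that something is new, unique, unknown or untested is made for them only; others in the source may bear on it.

Measured compounds:
compound 1 `C=Cc1cccc(-c2[nH]c3cc(OC)ccc3c(=O)c2C(=O)OCC)c1`; in an ADME assay on HEK293 cells (Homo sapiens) for cytotoxicity, read by luminescence, with a stated time of 72 h (on this read-out lower numbers stand for an effect already at smaller amounts and higher numbers for an effect only at larger amounts of compound), compound 1 gives > 22000 nM, a limit of the assay.
compound 2 `CCOC(=O)c1c(-c2cccc(OCC(C)C)c2)[nH]c2cc(OC)ccc2c1=O`; compound 2 gives > 22000 nM, a limit of the assay.
compound 3 `CCOC(=O)c1c(-c2cccc(OCc3ccccc3)c2)[nH]c2cc(OC)ccc2c1=O`; compound 3 gives > 22000 nM, a limit of the assay.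

Compound 2 therefore stands on no number in this assay, only on a limit, and the same holds for the two further values in the series, as the limit of > 22000 nM in this assay, at which 3 of the 3 values shown sit, records. None of the steps among the measured compounds can be read: a step that the two limits leave unreadable from compound 1 to compound 2, a step that the two limits leave unreadable from compound 1 to compound 3, and a step that the two limits leave unreadable from compound 2 to compound 3 all fall between two limits, so no size and no direction is available for any change on this part of the shared core.

The compound not yet measured is compound 4 `CCOC(=O)c1c(-c2cccc(NC(C)=O)c2)[nH]c2cc(OC)ccc2c1=O`. It differs from compound 2 by acetamido in place of isobutoxy on an aromatic carbon. Among the compounds with values here, the steps that bear on it are the three above, each unreadable, so the measured series gives no size for the step in this assay, in either direction, and nothing beyond the scatter is expected. The expected step that the limit leaves unreadable from compound 2 to compound 4 from compound 2 to compound 4 is therefore set at no change. Compound 4 is estimated at 30000 nM, with a range from 12000 nM to 90000 nM, most likely reported again as a limit.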

Compound 4, half-maximal effective concentration: > 22000 nM
Compound 4 gave a limit, no number; the forecaster's own chance of this, stated with the estimate: 85%; the middle value is on the limit's open side.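

The steps from compound 1, compound 2 and compound 3 to compound 4 cannot be read, as each runs between two limits: the limit of > 22000 nM in this assay, at which 4 of the 4 values shown sit.

The compounds shown leave open whether any change on the shared core would give a number rather than a limit in this assay, and so how large any such step would be.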